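Swapping methoxy for fluoro on the benzyl amide

A few compounds are considered here, and "the series" means these few. Any claim that something is new, unique, unknown or untested is made for them only; others in the source may bear on it.

Compound 3 `COc1ccc(CNC(=O)c2cc(Oc3ccc(/C=C/c4ccncc4)cc3)ccn2)cc1` stands at the lowest number of the three measured in a functional assay on A549 cells (Homo sapiens) for antiproliferative activity, read by CCK-8 assay, with a stated time of 48 h (on this read-out lower numbers stand for stronger inhibition and higher numbers for weaker inhibition), where compound 3 gives 19300 nM. Its nearest neighbour is compound 2 `COc1ccc(NC(=O)c2cc(Oc3ccc(/C=C/c4ccncc4)cc3)ccn2)cc1`, which in this assay gives 25600 nM; the step of a 1.3-fold lower number from compound 2 to compound 3 (0.12 log units; within the scatter) is within the scatter, so the two cannot be ranked against each other. Compound 1 `O=C(Nc1ccccc1)c1cc(Oc2ccc(/C=C/c3ccncc3)cc2)ccn1` gives 79700 nM, and the step of a 4.1-fold lower number from compound 1 to compound 3 (0.62 log units; beyond the scatter) is beyond the scatter.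

Compound 4 `O=C(NCc1ccc(F)cc1)c1cc(Oc2ccc(/C=C/c3ccncc3)cc2)ccn1` differs from compound 3 in one place: fluoro in place of methoxy on an aromatic carbon. Among the compounds with values here, only one measured step touches the group that leaves: the step of a 3.1-fold lower number from compound 1 to compound 2 (0.49 log units; beyond the scatter) came from adding a methoxy to an aromatic carbon. No measured compound carries fluoro, so the entering group has no precedent among these compounds. Because the step of a 3.1-fold lower number from compound 1 to compound 2 (0.49 log units; beyond the scatter) was modest, taking the methoxy away in compound 4 is expected to give back only part of it, and the expected step of a 1.5-fold higher number from compound 3 to compound 4 (0.16 log units; within the scatter) is a small rise in the number, possibly within the scatter. Compound 4 is estimated at 28000 nM, with a range from 10000 nM to 70000 nM.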

Compound 4, half-maximal inhibitory concentration: 18200 nM
The estimate for compound 4 lay 1.5-fold (0.19 log units) above the measured number; measured number inside the range.
By their numbers in this assay, from the lowest: compounds 4, 3 and 2 (each within the scatter of the next); then compound 1.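

In this assay, exchanging the methoxy for a fluoro on this ring gives a 1.1-fold lower number from compound 3 to compound 4 (0.03 log units; within the scatter), so the two groups cannot be told apart at this place, even though the fluoro is the smaller group and carries no hydrogen-bond acceptor. Compound 4 also cannot be separated from the 4-methoxyphenyl amide, with a 1.4-fold lower number from compound 2 to compound 4 (0.15 log units; within the scatter), while a 4.4-fold lower number from compound 1 to compound 4 (0.64 log units; beyond the scatter) leaves compound 1 clearly apart, so compounds 2, 3 and 4 sit together, each with a lower number than compound 1. No measured evidence bears on why the methoxy and fluoro compounds read alike.

Open, from the compounds shown here alone, is whether the benzyl amide with only hydrogen at this place would join that group. Also open, going by these compounds, is what an amine or a carboxylic acid here, or a longer chain in place of the benzyl link, would do.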